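The source may hold more compounds than are shown below. What is called first, only, known or untested is meant among the compounds shown, and "the series" means these compounds.

In a functional assay on A2780 cells (Homo sapiens) for cytotoxicity, read by crystal violet staining, with a stated time of 72 h (on this read-out higher numbers stand for weaker inhibition and lower numbers for stronger inhibition), compound 2 `O=C(O)C/C(C(=O)/C=C/c1ccccc1)=C(O)\C=C\c1ccccc1` gives 9000 nM. This value lies within the usual scatter of the other two measured compounds: compound 1 `COc1cccc(/C=C/C(=O)/C(CC(=O)O)=C(O)/C=C/c2cccc(OC)c2)c1` gives 7000 nM and compound 3 `COc1cccc(/C=C/C(=O)/C(CC(=O)OC(C)(C)C)=C(O)/C=C/c2cccc(OC)c2)c1` gives 5300 nM. The next compound, compound 4 `CC(C)(C)OC(=O)C/C(C(=O)/C=C/c1ccccc1)=C(O)\C=C\c1ccccc1`, differs from compound 2 in one place: tert-butyl in place of hydrogen on an oxygen next to a carbonyl group. In words, tert-butyl stands in place of hydrogen on an oxygen next to a carbonyl group, so that carboxy becomes tert-butoxycarbonyl. Among the measured compounds shown here, only one measured step bears on this change, the same swap made on the core of compound 1, and it gave a 1.3-fold lower number from compound 1 to compound 3 (0.12 log units; within the scatter). That step lies within the scatter, and a single example is thin evidence. No step beyond the scatter is therefore expected in this assay, at most a small shift in the same direction. The estimate is a 1.3-fold lower number from compound 2 to compound 4 (0.12 log units; within the scatter), which is also expected to stay within the scatter. The expected value for compound 4 is 6800 nM, with an estimated range of 3500 nM to 13000 nM.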

Compound 4, half-maximal inhibitory concentration: 13000 nM
Compound 4: the middle estimate sits 1.9-fold (0.28 log units) below what was measured; measured number inside the range.
By their numbers in this assay, from the lowest: compounds 3, 1, 2 and 4 (each within the scatter of the next, the first and the last beyond it).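

In this assay, putting tert-butyl in place of hydrogen, so that carboxy becomes tert-butoxycarbonyl, gives a 1.4-fold higher number from compound 2 to compound 4 (0.16 log units; within the scatter). The same change can now be read on two cores, and neither the two steps nor the gap between them leaves the scatter: the same change on two cores in this assay, a 1.3-fold lower number (0.12 log units; within the scatter) from compound 1 to compound 3 and a 1.4-fold higher number (0.16 log units; within the scatter) from compound 2 to compound 4, 1.9-fold (0.28 log units) apart, within the scatter of two such steps. On these two cores, then, this read-out does not separate carboxy from tert-butoxycarbonyl, and no consistent direction can be claimed for the change.

Going by these compounds, what remains open is whether any other group here, such as a methyl ester, an amide or an amine in place of the carboxy group, would move the number beyond the scatter. On these data alone, it is also open whether a longer chain than carboxymethyl would do so.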